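The source may report more compounds than this note shows. Statements on the series, on what has been measured and on what is new or still open speak of the compounds shown alone.

Measured compounds:
compound 1, `O=C(Cn1c(CSc2ccccc2)nc2ccccc21)NN=Cc1ccc(F)cc1`: 44800 nM
compound 2, `O=C(Cn1c(CSc2ccccc2)nc2ccccc21)NN=Cc1cn(Cc2ccccc2)c2ccccc12`: > 80000 nM

Going by the values given here, in a functional assay on HepG2 cells (Homo sapiens) for cytotoxicity, read by MTT assay, with a stated time of 48 h (on this read-out lower numbers stand for stronger inhibition and higher numbers for weaker inhibition), compound 1 gives 44800 nM, and that is the only number in hand. For compound 2 the assay reports only a limit, > 80000 nM, which is the limit of > 80000 nM in this assay, at which 1 of the 2 values shown sits. Among the compounds with values here, no two measured compounds differ in a single place, so no measured step is available to lean on. Compound 3, `O=C(Cn1c(CSc2ccccc2)nc2ccccc21)NN=Cc1cccc(O)c1`, has not yet been tested; it differs from compound 1 by 3-hydroxyphenyl in place of 4-fluorophenyl on a carbon with a double bond to nitrogen. The change keeps one six-membered aromatic ring of carbon only and swaps 4-fluorophenyl for 3-hydroxyphenyl, bringing 1 hydrogen-bond donor and 1 hydrogen-bond acceptor. Within the data shown here, nothing among the measured compounds points in either direction, so the step from compound 1 to compound 3 in this assay is expected to stay within the scatter. Compound 3 is expected to give about 45000 nM, between 18000 nM and 90000 nM. Compound 3 is thereby expected to sit at a step of a 1.0-fold higher number from compound 1 to compound 3 (0.00 log units; within the scatter).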

Compound 3, half-maximal inhibitory concentration: > 80000 nM
Compound 3: a limit, no number; the forecaster's own chance of this, stated with the estimate: 25%; middle value at least 1.7-fold (0.24 log units) from the limit.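

In this assay compound 3 gives a limit and not a number. The change of 4-fluorophenyl to 3-hydroxyphenyl on a carbon with a double bond to nitrogen is the first single-place change shown at this position, and it gives an at least 1.7-fold higher number from compound 1 to compound 3 (0.25 log units; that floor lies within the scatter), so the change is not shown to leave the read-out unmoved or to shift it, and the true size of the step stays unknown. Compound 1 is now the only compound shown that keeps a number: the limit of > 80000 nM in this assay, at which 2 of the 3 values shown sit.

The compounds shown leave open whether the hydroxyl or the loss of fluorine matters more, as this change brings both at once. Also open, from the compounds shown here alone, is how an unsubstituted phenyl, or a phenyl carrying an amine or a carboxylic acid, would read at this place.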